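Swapping a Sulfur Chain for a Branched Carbon Tail

A few compounds are considered here, and "the series" means these few. Any claim that something is new, unique, unknown or untested is made for them only; others in the source may bear on it.

Three compounds built on one shared core carry different side chains and amine groups. Compound 1 `CCSCCn1c(N2CCN(C)CC2)nc2ccccc21` is tested in a functional assay on ileum for inhibition of histamine H1 receptor (Cavia porcellus) (on this read-out higher numbers stand for weaker inhibition and lower numbers for stronger inhibition), where compound 1 gives 19 nM. Compound 3 `CCCOCCn1c(N2CCCN(C)CC2)nc2ccccc21` gives 16 nM in this assay. Compound 1 holds the higher of the two measured numbers, and compound 3 sits only a hair lower, a gap that stays inside the usual scatter of repeated measurements, so the two are best read as equal. Compound 2 `CCOCCn1c(N2CCN(C(c3ccccc3)c3ccccc3)CC2)nc2ccccc21` gives > 3000 nM in this assay, which is a limit rather than a measured number (the limit of > 3000 nM in this assay, at which 1 of the 3 values shown sits).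

Compound 4 `CC(C)CCn1c(N2CCN(C)CC2)nc2ccccc21` has not yet been measured. It differs from compound 1 in one place: isopropyl in place of ethylsulfanyl on a saturated chain carbon, two bonds along the chain from an aromatic nitrogen. Going by the values given here, no pair of measured compounds separated by a single change is available, so there is no direct guide for this swap. What is known is that compound 3, which differs from compound 1 on both the chain and the amine, gives a number close to that of compound 1, while compound 2, which carries a much larger amine group, sits at the limit. The change in compound 4 touches only the chain. Compound 4 is therefore expected to stay within the scatter of compound 1, with a step of a 1.3-fold higher number from compound 1 to compound 4 (0.12 log units; within the scatter) estimated as none beyond the scatter. The estimate for compound 4 is 25 nM, in a range from 8 nM to 80 nM.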

Compound 4, half-maximal inhibitory concentration: 1400 nM
Compound 4: middle estimate off by 56-fold (1.75 log units), on the low side; the measured number lies above the stated range.
By their numbers in this assay, from the lowest: compounds 3 and 1 (each within the scatter of the next); then compound 4. At a limit, above all of these: compound 2.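

Here a change in one place can be read on its own, and it matters greatly: in this assay, placing isopropyl where ethylsulfanyl stood gives a 74-fold higher number from compound 1 to compound 4 (1.87 log units; beyond the scatter) on the read-out, a large loss of inhibition. Both groups count the same number of heavy atoms, so this step shows that two groups matched on that count can still give very different numbers at this position; what the count does separate is that ethylsulfanyl holds a sulfur and a hydrogen-bond acceptor, while isopropyl holds carbon alone and no acceptor. The earlier compounds shown here could not show this, since compound 3 differs from compound 1 on both the chain and the amine, and compound 2 also differs from compound 1 in more than one place.

No measurement shown here gives a reason for this step.
As far as these compounds go, whether the sulfur or the branching of the new group matters more stays open, and a straight propyl group or a methoxy group at this place would help tell the two apart.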